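The source may report more compounds than this note shows. Statements on the series, on what has been measured and on what is new or still open speak of the compounds shown alone.

Measured so far in a functional assay on ileum for inhibition of histamine H1 receptor (Cavia porcellus); a higher number here means a weaker inhibitor, a lower number a stronger inhibitor:

compound 1 `CCCOCCn1c(N2CCN(C)CC2)nc2ccccc21`: 20 nM
compound 2 `CCOCCn1c(N2CCNCC2)nc2ccccc21`: 11 nM
compound 3 `CCCCCN1CCN(c2nc3ccccc3n2CCOCC)CC1`: 30 nM

Compound 1 sits second highest of the three numbers. Its nearest neighbour is compound 3, whose value lies within the usual scatter of that of compound 1; compound 2 gives the lower number, but this gap also stays within the scatter, so no order among the three can be read from these values.

Compound 4 `CCCC(C)n1c(N2CCN(C)CC2)nc2ccccc21` is the next candidate. It differs from compound 1 in one place: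

1-methylbutyl in place of 2-propoxyethyl on an aromatic nitrogen

Going by the values given here, the only single-point step measured is a 2.7-fold higher number from compound 2 to compound 3 (0.44 log units; beyond the scatter), and that step concerns the substituent on an amine nitrogen in a ring, not the aromatic nitrogen that is altered here. Among the compounds with values here, compounds 1 and 3 differ from each other in two places, so they give no clean step either. Within the data shown here, no measured step therefore bears on the change from compound 1 to compound 4, and the expectation is that the step of a 1.3-fold higher number from compound 1 to compound 4 (0.10 log units; within the scatter) stays within the scatter. On that basis compound 4 is estimated at 25 nM, with a range from 8 nM to 80 nM expected to cover most repeats.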

Compound 4, half-maximal inhibitory concentration: 1400 nM
The estimate for compound 4 lay 56-fold (1.75 log units) below the measured number, and the stated range ends below it.
By their numbers in this assay, from the lowest: compounds 2, 1 and 3 (each within the scatter of the next, the first and the last beyond it); then compound 4.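

The aromatic nitrogen proves to be a sensitive position in this assay: replacing 2-propoxyethyl with 1-methylbutyl gives a 70-fold higher number from compound 1 to compound 4 (1.85 log units; beyond the scatter) on an otherwise unchanged core. All three earlier compounds carry a chain with an ether oxygen at this nitrogen, so they gave no view of how a purely hydrocarbon, branched chain is tolerated here. No available evidence accounts for the size of this step.

The change removes the ether oxygen and introduces branching at once, and the compounds shown do not separate these two differences. As far as these compounds go, a straight hexyl chain or a 2-hydroxyethyl group on this nitrogen would help to separate them, and whether the step carries over to the core of compound 2 also remains open.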